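A few compounds are considered here, and "the series" means these few. Any claim that something is new, unique, unknown or untested is made for them only; others in the source may bear on it.

Compound 1, `O=C(Nc1cccc(-c2cccc(NC(=O)C(Cl)Cl)c2)c1)C(Cl)Cl`: 47900 nM
Compound 2, `O=C(Nc1cccc(-c2ccc(-c3ccccc3)cc2)c1)C(Cl)Cl`, a limit: > 50000 nM
Compound 3, `O=C(Nc1cccc(-c2ccccc2)c1)C(Cl)Cl`: 8900 nM

In a functional assay on A549 cells (Homo sapiens) for cytotoxicity, read by MTT assay, with a stated time of 68 h (on this read-out lower numbers stand for stronger inhibition and higher numbers for weaker inhibition), compound 3 gives the lowest of the two numbers. Compound 1 sits higher, by a 5.4-fold lower number from compound 1 to compound 3 (0.73 log units; beyond the scatter). The value of compound 2 is a limit (the limit of > 50000 nM in this assay, at which 1 of the 3 values shown sits), and the step of an at least 5.6-fold lower number from compound 2 to compound 3 (0.74 log units; beyond the scatter) is therefore only a bound. Compound 4, `Cc1cccc(-c2cccc(NC(=O)C(Cl)Cl)c2)c1`, differs from compound 3 by methyl in place of hydrogen on an aromatic carbon. Both measured steps concern a much larger group at that position, and neither tells how a methyl behaves, so a small change in either direction is expected, one that may stay within the scatter: a 1.0-fold higher number from compound 3 to compound 4 (0.00 log units; within the scatter). Compound 4 is therefore estimated at 9000 nM, within 3000 nM to 27000 nM.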

Compound 4, half-maximal inhibitory concentration: 8700 nM
The estimate for compound 4 lay 1.0-fold (0.01 log units) above the measured number; the measured number falls inside the stated range.
By their numbers in this assay, from the lowest: compounds 4 and 3 (each within the scatter of the next); then compound 1. At a limit, above all of these: compound 2.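

In this assay compound 4 shows that a methyl on this aromatic carbon changes nothing beyond the scatter (a 1.0-fold lower number from compound 3 to compound 4 (0.01 log units; within the scatter)). Methyl in place of ((dichloromethyl)carbonyl)amino gives a step beyond the scatter (a 5.5-fold lower number from compound 1 to compound 4 (0.74 log units; beyond the scatter)), of about the same size as the one with hydrogen in that place (a 5.4-fold lower number from compound 1 to compound 3 (0.73 log units; beyond the scatter)). Nothing given here accounts for this result.

The compounds shown leave open whether an amine, a carboxylic acid or a longer chain such as propyl at this position would move the number. They also leave open whether a methyl elsewhere on the ring would behave the same way.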